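Compound 1 to compound 3: cyclopropyl for dichlorophenyl

The source may report more compounds than this note shows. Statements on the series, on what has been measured and on what is new or still open speak of the compounds shown alone.

Compound 1 `CNc1nc(NCc2ccc(Cl)cc2Cl)cc(-c2ccccn2)n1` holds the lowest number of the two measured in a functional assay on HEK293 cells for agonist activity at G-protein coupled receptor 39 (Mus musculus), read by inositol phosphate accumulation (on this read-out lower numbers stand for an effect already at smaller amounts and higher numbers for an effect only at larger amounts of compound), with 0.5 nM; compound 2 `CNc1nc(NCc2ccc(NC(C)=O)cc2)cc(-c2ccccn2)n1` gives 2 nM in this assay. Compound 3 `CNc1nc(NCC2CC2)cc(-c2ccccn2)n1` is not yet measured. It differs from compound 1 by cyclopropyl in place of 2,4-dichlorophenyl on a saturated chain carbon bound to a nitrogen on an aromatic ring. Going by the values given here, no pair of measured compounds shows this change, so its size is unknown. A shift toward higher numbers beyond the scatter is expected, with a 40-fold higher number from compound 1 to compound 3 (1.60 log units; beyond the scatter) from compound 1 to compound 3. Compound 3 is estimated at 20 nM in this assay, likely between 3 nM and 150 nM.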

Compound 3, half-maximal effective concentration: 115 nM
Beside the measured number, compound 3's estimate is 5.8-fold (0.76 log units) below it; low and high end bracket the measured number.
By their numbers in this assay, from the lowest: compound 1; then compound 2; then compound 3.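

The group on the saturated chain carbon bound to a nitrogen on an aromatic ring now proves decisive: cyclopropyl in place of 2,4-dichlorophenyl gives a 230-fold higher number from compound 1 to compound 3 (2.36 log units; beyond the scatter) in this assay. The core of compound 1 therefore does not hold the low number without a suitable group here. Nothing at hand explains the size of this step.

Open, from the compounds shown here alone, is which part of 2,4-dichlorophenyl carries the effect, the six-membered aromatic ring or its chlorine atoms. Unsubstituted phenyl, a single chlorine on that ring, or a longer alkyl chain would separate these.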